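Swapping a halogenated phenyl ring: expected lipophilicity of compound 4

The source may report more compounds than this note shows. Statements on the series, on what has been measured and on what is new or still open speak of the compounds shown alone.

Measured compounds:
- compound 1, `CCCCC(Nc1c(C#N)c(-c2ccc(-c3ccccc3OCC)cc2)nc2cnccc12)C(N)=O`, 3.6
- compound 2, `CC[C@H](Nc1c(C#N)c(-c2ccc(Br)cc2)nc2cnccc12)C(N)=O`, 2.3
- compound 3, `CC[C@@H](Nc1c(C#N)c(-c2ccc(-c3cccc(Cl)c3F)cc2)nc2cnccc12)C(N)=O`, 3.1

All three share one core and differ in the group carried on the outer aromatic ring. In a physicochemical assay for lipophilicity, read by HPLC, at pH 7.5 (a higher number here means a more lipophilic compound, a lower number a more polar compound), compound 3 gives 3.1, the second highest of the three numbers. Compound 1 lies above it by a gap beyond the usual scatter, and compound 2, which carries a bromine in place of a second ring, lies below it by a larger gap, also beyond the scatter.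

The unmeasured compound 4, `CC[C@@H](Nc1c(C#N)c(-c2ccc(-c3ccc(Cl)cc3)cc2)nc2cnccc12)C(N)=O`, keeps everything of compound 3 except the outer ring: 4-chlorophenyl in place of 3-chloro-2-fluorophenyl on an aromatic carbon. The change removes one fluorine and shifts the chlorine to a different position on that ring; the rest of the molecule is untouched.

Going by the values given here, no pair of measured compounds differs in only one place, so there is no direct precedent for a step of this kind. The loss of a single fluorine and the relocation of a chlorine would be expected to move the number only slightly, and downward if at all; the step from compound 3 to compound 4 is estimated at a number 0.10 log units lower from compound 3 to compound 4 (within the scatter), within the scatter. Compound 4 is therefore expected to give 3 in this assay, with a likely range from 2.6 to 3.4.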

Compound 4, distribution coefficient: 3.1
Compound 4: the middle estimate sits 0.10 log units below what was measured; the range from low to high includes it.
By their numbers in this assay, from the lowest: compound 2; then compounds 3 and 4 (each within the scatter of the next); then compound 1.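

In this assay, putting 4-chlorophenyl in place of 3-chloro-2-fluorophenyl on this aromatic carbon gives no change at the digits printed from compound 3 to compound 4 (within the scatter). Going by these compounds alone, this is the first step in the set that changes only one place in the molecule, and it shows that, for this pair, the outer ring can lose its fluorine and carry its chlorine at a different position with no readable shift in the number, although the single step cannot separate those two alterations. Nothing available gives a reason for this result.

Going by these compounds, how far this tolerance extends remains open, since both rings in the step are halogenated phenyl rings and a single pair cannot support a wider rule. A plain phenyl ring with no halogen would show whether the chlorine matters to this number, while an outer ring carrying an amine or a carboxylic acid in place of the chlorine would test a very different kind of group at the same place.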